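Trimming a Fluorine on the Tail: Expected Permeability

The compounds below may be only part of what the source reports. "The series", "measured", "known", "first", "only" and "open" are said of these compounds alone.

Going by the values given here, compound 2 `Cc1c(CCCC(=O)O)c2cccc(/C=C/c3ccc(OCCCCc4cc(F)c(F)c(F)c4F)cc3)c2n1CC(=O)O` is one of two compounds measured in a physicochemical assay for permeability, using PAMPA, with a stated time of 4 h, at pH 6.2, tested at 50 uM; on this read-out higher numbers stand for higher permeability and lower numbers for lower permeability; compound 2 gives 1.8 10^-6 cm/s, the lower of the two numbers. Compound 1 `Cc1c(F)cccc1CCCCOc1ccc(/C=C/c2cccc3c(CCCC(=O)O)c(C)n(CC(=O)O)c23)cc1` gives 4 10^-6 cm/s. Among the compounds with values here, the single measured step runs between these two: a 2.2-fold lower number from compound 1 to compound 2 (0.35 log units; beyond the scatter). Compound 3 `Cc1c(CCCC(=O)O)c2cccc(/C=C/c3ccc(OCCCCc4c(F)ccc(F)c4F)cc3)c2n1CC(=O)O` has not yet been measured; it differs from compound 2 in this way: 2,3,6-trifluorophenyl in place of 2,3,4,5-tetrafluorophenyl on a saturated chain carbon, four bonds along the chain from an oxygen on an aromatic ring. Within the data shown here, no measured step swaps one fluorinated phenyl ring for another, so the step from compound 1 to compound 2 bears on it only loosely, and that step was modest. A change of this size, which keeps the chain, the ring and the shared core, is expected to move the number little, if at all beyond the scatter. For compound 3 the expected step is a 1.2-fold higher number from compound 2 to compound 3 (0.09 log units; within the scatter). Compound 3 is therefore estimated at 2.2 10^-6 cm/s, with a range from 1.1 10^-6 cm/s to 4.4 10^-6 cm/s.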

Compound 3, apparent permeability: 4.4 10^-6 cm/s
Compound 3: middle estimate off by 2.0-fold (0.30 log units), on the low side; the measured number falls inside the stated range.
By their numbers in this assay, from the lowest: compound 2; then compounds 1 and 3 (each within the scatter of the next).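

Moving from 2,3,4,5-tetrafluorophenyl to 2,3,6-trifluorophenyl on this chain is not a silent swap in this assay: the result is a 2.4-fold higher number from compound 2 to compound 3 (0.39 log units; beyond the scatter). Against the 3-fluoro-2-methylphenyl ring, the same trifluorophenyl ring gives a 1.1-fold higher number from compound 1 to compound 3 (0.04 log units; within the scatter), so among these three rings only the 2,3,4,5-tetrafluorophenyl of compound 2 stands apart. The number therefore does not simply climb as fluorines leave the ring, since compound 1 and compound 3 lie within the scatter of each other despite carrying different fluorine patterns.

No measurement shown here explains why the rings differ. Going by these compounds, it also remains open how a plain phenyl ring without fluorine, a ring bearing an amine, or a longer chain would read at this position.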